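Furan-3-yl to thiophen-3-yl in a cytotoxicity test

The source may report more compounds than this note shows. Statements on the series, on what has been measured and on what is new or still open speak of the compounds shown alone.

In a toxicity assay on Huh-7 cells (Homo sapiens) for cytotoxicity, with a stated time of 3 days (on this read-out higher numbers stand for lower toxicity in this test and lower numbers for higher toxicity in this test), compound 1 (`C[C@@]1(O)[C@H](O)[C@@H](CO)O[C@H]1n1cc(I)c2c(N)ncnc21`), which carries iodo on an aromatic carbon, gives 19800 nM. Compound 2 (`C[C@@]1(O)[C@H](O)[C@@H](CO)O[C@H]1n1cc(-c2ccccc2)c2c(N)ncnc21`), with phenyl in that place, reads > 44000 nM, which is a limit and not a number. Compound 3 (`C[C@@]1(O)[C@H](O)[C@@H](CO)O[C@H]1n1cc(-c2ccoc2)c2c(N)ncnc21`), with furan-3-yl there, reads > 44000 nM, which is also a limit. Compound 3 therefore stands at the limit of > 44000 nM in this assay, at which 2 of the 3 values shown sit.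

Compound 4 (`C[C@@]1(O)[C@H](O)[C@@H](CO)O[C@H]1n1cc(-c2ccsc2)c2c(N)ncnc21`) has thiophen-3-yl in place of furan-3-yl on an aromatic carbon.

Two measured steps replace iodo with an aromatic ring, and both are at least modest: an at least 2.2-fold higher number from compound 1 to compound 2 (0.34 log units; beyond the scatter) and an at least 2.2-fold higher number from compound 1 to compound 3 (0.34 log units; beyond the scatter). The closest comparison, one aromatic ring for another, gives a step that the two limits leave unreadable from compound 2 to compound 3. Compound 4 keeps an aromatic ring in place of iodo, as compound 3 does in an at least 2.2-fold higher number from compound 1 to compound 3 (0.34 log units; beyond the scatter), so low toxicity in this assay should persist. The expected change is a step that the limit leaves unreadable from compound 3 to compound 4, with no step beyond the scatter anticipated. Compound 4 is estimated at 50000 nM, with an expected range from 25000 nM to 100000 nM.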

Compound 4, half-maximal cytotoxic concentration: > 44000 nM
Compound 4 gave a limit, no number; the forecaster's own chance of this, stated with the estimate: 70%; the middle value lies beyond the limit too.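

In this assay, a third aromatic ring now behaves like the first two: thiophen-3-yl, with sulfur where furan-3-yl has oxygen, gives an at least 2.2-fold higher number from compound 1 to compound 4 (0.34 log units; beyond the scatter). The change at this position, on an aromatic carbon two ring bonds from the ring nitrogen, therefore holds for phenyl, furan-3-yl and thiophen-3-yl alike, and the read-out for most of the series now rests on one limit: the limit of > 44000 nM in this assay, at which 3 of the 4 values shown sit. The steps among compound 2, compound 3 and compound 4 cannot be read, so no order among these three rings can be given.

The compounds shown leave open what actual numbers lie behind these limits. They also leave open whether a non-aromatic group at this position, such as an amine or a short ethyl chain, would read like compound 1 or like the ring-bearing compounds.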